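The source may report more compounds than this note shows. Statements on the series, on what has been measured and on what is new or still open speak of the compounds shown alone.

In an ADME assay on MT2 cells (Homo sapiens) for cytotoxicity, read by XTT assay, with a stated time of 4 days (on this read-out higher numbers stand for lower toxicity in this test and lower numbers for higher toxicity in this test), compound 1 (`Cc1nc(C(NC(=O)C(=O)Nc2ccc(Cl)cc2)C2CCCN2)sc1CO`) gives 45000 nM and compound 3 (`Cc1nc(C(NC(=O)C(=O)Nc2ccc(Cl)cc2)C2CCCCN2C)sc1CCO`) gives 88000 nM, two values within the scatter of each other. For compound 2 (`Cc1nc(C(NC(=O)C(=O)Nc2ccc(Cl)cc2)C2CCNCC2)sc1CCO`), this assay returns only a limit, > 78500 nM. For the measured compounds named here, the one measured step, a step that the limit leaves unreadable from compound 2 to compound 3, therefore offers no size to carry forward. Compound 4 (`Cc1nc(C(NC(=O)C(=O)Nc2ccc(Cl)cc2)C2CCCN2)sc1CCO`) carries pyrrolidin-2-yl in place of the 1-methylpiperidin-2-yl of compound 3, on a saturated chain carbon bound to an amide-type nitrogen and an aromatic carbon: pyrrolidin-2-yl in place of 1-methylpiperidin-2-yl on a saturated chain carbon bound to an amide-type nitrogen and an aromatic carbon. Compound 1, which also carries pyrrolidin-2-yl, gives 45000 nM, so no step beyond the scatter is expected in this assay. The estimated step is a 1.5-fold lower number from compound 3 to compound 4 (0.17 log units; within the scatter). For compound 4 the expected value is 60000 nM, with an estimated range of 28000 nM to 125000 nM.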

Compound 4, half-maximal cytotoxic concentration: 42000 nM
Compound 4: middle estimate off by 1.4-fold (0.15 log units), on the high side; measured number inside the range.
By their numbers in this assay, from the lowest: compounds 4, 1 and 3 (each within the scatter of the next, the first and the last beyond it).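

In this assay, for the compounds shown here, pyrrolidin-2-yl in place of 1-methylpiperidin-2-yl gives the first step at this position with a readable size, a 2.1-fold lower number from compound 3 to compound 4 (0.32 log units; beyond the scatter), modest but beyond the scatter. Hydroxymethyl in place of hydroxy on the chain carbon bound to an aromatic carbon gives a 1.1-fold lower number from compound 1 to compound 4 (0.03 log units; within the scatter), so that change shows no readable effect. For compound 2 only a limit stands, and an at least 1.8-fold lower number from compound 2 to compound 4 (0.27 log units; that floor lies within the scatter) is therefore a floor: the limit of > 78500 nM in this assay, at which 1 of the 4 values shown sits. The step from compound 3 changes ring size and removes the methyl together. As far as these compounds go, how much each contributes stays open, and a 1-methylpyrrolidin-2-yl group at this place would separate the two.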